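The source may report more compounds than this note shows. Statements on the series, on what has been measured and on what is new or still open speak of the compounds shown alone.

Within the data shown here, compound 3 `O=C([C@@H]1C[C@H](N2CCN(c3ccccc3Cl)CC2)CN1)N1CCSC1` gives 10.9 nM in an assay on a cell-free system (plasma) for inhibition of Dipeptidyl peptidase 4 (Rattus norvegicus), read by fluorescence (a higher number here means a weaker inhibitor, a lower number a stronger inhibitor), and stands second highest of the three numbers so far: compound 1 `O=C([C@@H]1C[C@H](N2CCN(c3ccc(Cl)c(Cl)c3)CC2)CN1)N1CCSC1` gives 4.2 nM, while compound 2 `COc1ccc(N2CCN([C@@H]3CN[C@H](C(=O)N4CCSC4)C3)CC2)cc1` gives 16.9 nM. Compound 4 `N#Cc1ccc(N2CCN([C@@H]3CN[C@H](C(=O)N4CCSC4)C3)CC2)cc1` carries 4-cyanophenyl in place of 2-chlorophenyl on an amine nitrogen in a ring. Among the measured compounds shown here, the steps that bear on this change are a 2.6-fold higher number from compound 1 to compound 3 (0.41 log units; beyond the scatter) and a 4.0-fold higher number from compound 1 to compound 2 (0.60 log units; beyond the scatter), both modest, whereas a 1.6-fold lower number from compound 2 to compound 3 (0.19 log units; within the scatter) lies within the scatter. The closest guide is the 4-methoxyphenyl of compound 2, whose value of 16.9 nM sits within the scatter of compound 3. For compound 4 the expected step is therefore a 1.4-fold higher number from compound 3 to compound 4 (0.14 log units; within the scatter), not beyond the scatter. Compound 4 is estimated at 15 nM, with a range from 6 nM to 40 nM.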

Compound 4, half-maximal inhibitory concentration: 4.7 nM
Compound 4: middle estimate off by 3.2-fold (0.50 log units), on the high side; measured number outside the range, below it.
By their numbers in this assay, from the lowest: compounds 1 and 4 (each within the scatter of the next); then compounds 3 and 2 (each within the scatter of the next).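

In this assay, 4-cyanophenyl on the ring amine nitrogen gives a 2.3-fold lower number from compound 3 to compound 4 (0.37 log units; beyond the scatter), and cyano in place of methoxy on the aromatic carbon gives a 3.6-fold lower number from compound 2 to compound 4 (0.56 log units; beyond the scatter), so this position separates groups in a way the within-scatter pair of compound 2 and compound 3 did not. Among these compounds, the single cyano group stands level with 3,4-dichlorophenyl, at a 1.1-fold higher number from compound 1 to compound 4 (0.05 log units; within the scatter). Nothing shown gives a reason for these differences. From the compounds shown here alone, it remains open whether a carboxylic acid, an amide or a trifluoromethyl group on the phenyl ring would read like cyano or like methoxy.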